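Swapping the pendant aryl group on the shared core

The compounds below may be only part of what the source reports. "The series", "measured", "known", "first", "only" and "open" are said of these compounds alone.

Measured compounds:
- compound 1 `O=C1N=C(N2N=C(c3ccccc3)CC2c2ccccc2O)S/C1=C1/C(=O)Nc2ccccc21`: 4770 nM
- compound 2 `O=C1N=C(N2N=C(c3ccccc3)CC2c2ccccc2O)S/C1=C1/C(=O)Nc2ccc(Br)cc21`: 800 nM

In a functional assay on cells (Cancer cell lines, Homo sapiens) for cytotoxicity, read by sulforhodamine B assay, with a stated time of 48 h (on this read-out higher numbers stand for weaker inhibition of growth and lower numbers for stronger inhibition of growth), compound 1 gives 4770 nM, the highest of the two numbers. Among the compounds with values here, its nearest neighbour is compound 2, which differs only by bromo in place of hydrogen on an aromatic carbon; that step, a 6.0-fold lower number from compound 1 to compound 2 (0.78 log units; beyond the scatter), is the only measured step in the set.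

Compound 3 `COc1ccc(C2CC(c3ccccc3)=NN2C2=NC(=O)/C(=C3\C(=O)Nc4ccccc43)S2)cc1` is not yet measured. It differs from compound 1 by 4-methoxyphenyl in place of 2-hydroxyphenyl on a saturated ring carbon. Within the data shown here, no measured step touches this part of the core; the single known step concerns the aromatic ring on the other side of the molecule, so it bears only indirectly on the present change. Among the measured compounds shown here, with no direct precedent, the expectation for compound 3 is a number close to that of compound 1, with the step of a 1.0-fold higher number from compound 1 to compound 3 (0.02 log units; within the scatter) expected to stay within the usual scatter. Compound 3 is therefore estimated at 5000 nM, with a range from 1500 nM to 16000 nM.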

Compound 3, concentration for total growth inhibition: 4580 nM
Compound 3: middle estimate off by 1.1-fold (0.04 log units), on the high side; the measured number falls inside the stated range.
By their numbers in this assay, from the lowest: compound 2; then compounds 3 and 1 (each within the scatter of the next).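

In this assay the saturated ring carbon of the five-membered ring, with 4-methoxyphenyl in place of 2-hydroxyphenyl, gives a 1.0-fold lower number from compound 1 to compound 3 (0.02 log units; within the scatter) and so adds a second part of the molecule to the aromatic ring touched by the bromo step. On this read-out compound 1 and compound 3 cannot be told apart, even though 2-hydroxyphenyl carries a hydrogen-bond donor and 4-methoxyphenyl carries none, so in this pair the donor count of the group at this carbon does not separate the two numbers. No outside information bears on why the two compounds read alike.

Going by these compounds, because both aryl groups here carry a single oxygen substituent, it remains open whether a phenyl ring bearing an amine or a carboxylic acid, or a plain alkyl chain in place of the aryl group, would read differently at this carbon. Also open is whether the bromo step, a 6.0-fold lower number from compound 1 to compound 2 (0.78 log units; beyond the scatter) in the 2-hydroxyphenyl series, would carry over to a compound with 4-methoxyphenyl at this carbon, since that pairing is not among the compounds shown.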